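From furan-3-yl to ethynyl, starting at a limit

The compounds below may be only part of what the source reports. "The series", "measured", "known", "first", "only" and "open" are said of these compounds alone.

Values in a functional assay on CCRF-CEM cells (Homo sapiens), read by MTT assay, with a stated time of 72 h; on this read-out lower numbers stand for stronger inhibition and higher numbers for weaker inhibition:
- Compound 1 `CN(C)c1ncnc2c1c(-c1cc3ccccc3o1)cn2[C@@H]1O[C@H](CO)[C@@H](O)[C@H]1O`: > 20000 nM (a limit)
- Compound 2 `Cc1ncnc2c1c(-c1cc3ccccc3o1)cn2[C@@H]1O[C@H](CO)[C@@H](O)[C@H]1O`: 17300 nM
- Compound 3 `Cc1nc(N)c2c(-c3ccoc3)cn([C@@H]3O[C@H](CO)[C@@H](O)[C@H]3O)c2n1`: > 100000 nM (a limit)

Compound 3 gives no number, only a limit, at > 100000 nM. Compound 4 `C#Cc1cn([C@@H]2O[C@H](CO)[C@@H](O)[C@H]2O)c2nc(C)nc(N)c12` has ethynyl in place of furan-3-yl on an aromatic carbon.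

Among the measured compounds shown here, only one measured step is available: an at least 1.1-fold lower number from compound 1 to compound 2 (0.06 log units; that floor lies within the scatter). It is methyl in place of dimethylamino on an aromatic carbon, a different exchange from this one, so it gives little guidance on size. Compound 2 does show that a compound in this set can reach a number, at 17300 nM. In this assay, a lower number is therefore expected, although the size of the change is poorly fixed and another limit remains possible.

The expected change is an at least 6.6-fold lower number from compound 3 to compound 4 (0.82 log units; beyond the scatter). For compound 4, the estimate is 15000 nM, with an expected range of 1000 nM to 100000 nM.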

Compound 4, half-maximal inhibitory concentration: > 20000 nM
Compound 4: a limit, no number (the forecaster's own chance of this, stated with the estimate: 40%); at least 1.3-fold (0.12 log units) between middle value and limit.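

Compound 3 and compound 4 each give only a limit in this assay, not a number, and the step between them cannot be read. The compounds shown leave open whether ethynyl in place of furan-3-yl changes the inhibition at all, and by how much.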